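Fluoro in Place of Methoxy: Expected Cytotoxicity of Compound 3

The source may hold more compounds than are shown below. What is called first, only, known or untested is meant among the compounds shown, and "the series" means these compounds.

Compound 2 `COc1ccc(C(=O)NC[C@H]2c3[nH]c4ccccc4c3C[C@H]3[C@H]4c5[nH]c6ccccc6c5C[C@@H]([C@H](C#N)N23)N4C)cc1` gives 430 nM in a functional assay on HCT-116 cells (Homo sapiens) for cytotoxicity, read by MTT assay, with a stated time of 72 h; on this read-out lower numbers stand for stronger inhibition and higher numbers for weaker inhibition. Among the compounds with values here, of the two values measured so far it is the smaller, yet the step of a 1.5-fold lower number from compound 1 to compound 2 (0.17 log units; within the scatter) lies within the scatter, so the two compounds cannot be told apart. Compound 1 `CN1[C@@H]2c3[nH]c4ccccc4c3C[C@H]1[C@H](C#N)N1[C@@H](CNC(=O)c3ccc(Cl)cc3)c3[nH]c4ccccc4c3C[C@@H]21` gives 630 nM in this assay. Compound 3 `CN1[C@@H]2c3[nH]c4ccccc4c3C[C@H]1[C@H](C#N)N1[C@@H](CNC(=O)c3ccc(F)cc3)c3[nH]c4ccccc4c3C[C@@H]21` has not been measured. It differs from compound 2 by fluoro in place of methoxy on an aromatic carbon, which read one bond further out is 4-methoxyphenyl to 4-fluorophenyl. Within the data shown here, the only measured step bearing on this change is the swap of chloro for methoxy at the same aromatic carbon, a 1.5-fold lower number from compound 1 to compound 2 (0.17 log units; within the scatter), which stayed within the scatter. No step beyond the scatter is therefore expected for compound 3 in this assay. The expected step of a 1.2-fold higher number from compound 2 to compound 3 (0.07 log units; within the scatter) is accordingly small. Compound 3 is estimated to give about 500 nM, between 250 nM and 1000 nM.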

Compound 3, half-maximal inhibitory concentration: 140 nM
Beside the measured number, compound 3's estimate is 3.6-fold (0.55 log units) above it; the measured number lies below the stated range.
By their numbers in this assay, from the lowest: compound 3; then compounds 2 and 1 (each within the scatter of the next).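

In this assay the group on this aromatic carbon proves able to shift the number beyond the scatter: the change shows a 3.1-fold lower number from compound 2 to compound 3 (0.49 log units; beyond the scatter) and, with chloro as the starting point, a 4.5-fold lower number from compound 1 to compound 3 (0.65 log units; beyond the scatter) as well. The earlier swap of chloro for methoxy had shown no step that could be read, so this is the first sign that the position responds to its substituent, and fluoro stands apart from both other groups. No simple halogen-against-methoxy pattern follows, since compound 1, with chloro, goes against it by staying within the scatter of compound 2, and nothing available explains the effect of fluoro.

Going by these compounds, it remains open how a hydrogen, an amine or a trifluoromethyl group on the same carbon would compare with fluoro. On these data alone, whether the advantage of compound 3 extends to other cell lines also remains open.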